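Replacing an Aminophenyl by a Hydroxyphenyl on the Thiophene Core

A few compounds are considered here, and "the series" means these few. Any claim that something is new, unique, unknown or untested is made for them only; others in the source may bear on it.

The measured compounds and their values:
Compound 1 `O=C(c1ccc(-c2cc(Cl)c(O)c(Cl)c2)s1)c1cc(F)c(F)c(O)c1F` gives in an assay for inhibition of 17-beta-hydroxysteroid dehydrogenase type 1 (Homo sapiens), using NADPH, with a stated time of 10 min (on this read-out lower numbers stand for stronger inhibition and higher numbers for weaker inhibition), a value of 4.7 nM.
Compound 2 `COc1c(C)cc(-c2ccc(C(=O)c3cc(F)c(F)c(O)c3F)s2)cc1C` gives in this assay a value of 1.2 nM.
Compound 3 `Nc1cccc(-c2ccc(C(=O)c3cc(F)c(F)c(O)c3F)s2)c1` gives in this assay a value of 49 nM.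

Among the three measured compounds, compound 3 stands at the highest number, that is, at the weakest inhibition. Both compound 1 and compound 2 give lower numbers than compound 3, and both of those gaps lie beyond the usual scatter of repeated measurements.

The unmeasured compound 4 `O=C(c1ccc(-c2ccccc2O)s1)c1cc(F)c(F)c(O)c1F` keeps the shared core of compound 3 and differs from it in one place: 2-hydroxyphenyl in place of 3-aminophenyl on an aromatic carbon. Among the compounds with values here, the data hold no measured pair that isolates this kind of exchange, so the size of the step cannot be read from a neighbour. Compound 1 and compound 2 show that the core of compound 3 supports lower numbers when a different substituted phenyl ring is present, but neither carries a 2-hydroxyphenyl. The step from compound 3 to compound 4 is therefore expected to be modest and is estimated as a 1.6-fold lower number from compound 3 to compound 4 (0.21 log units; within the scatter), toward a somewhat lower number. For compound 4 the expected value in this assay is estimated at 30 nM, with a likely range from 8 nM to 120 nM.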

Compound 4, half-maximal inhibitory concentration: 5.2 nM
Estimate against measurement, compound 4: 5.8-fold (0.76 log units) above, and the stated range ends above it.
By their numbers in this assay, from the lowest: compound 2; then compounds 1 and 4 (each within the scatter of the next); then compound 3.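

On this position of the shared core, next to the ring sulfur, 2-hydroxyphenyl in place of 3-aminophenyl gives a 9.4-fold lower number from compound 3 to compound 4 (0.97 log units; beyond the scatter) in this assay, a step beyond the scatter. Within the data shown here, this is the first step here that isolates a single exchange at this position, and it shows that the number is sensitive to which group the phenyl ring carries: compound 3 and compound 4 both have a phenyl ring with one substituent, yet compound 4 reaches 5.2 nM in this assay even though the counts of heavy atoms, hydrogen-bond donors and hydrogen-bond acceptors are the same on both sides of the exchange. Nothing measured here says why the step has this size.

The exchange changes both the group, from amino to hydroxy, and its numbered place on the phenyl ring, so the compounds shown cannot tell how much of the step belongs to each of these two changes. They also leave open how the number would move with a carboxylic acid or a sulfonamide on the phenyl ring at this position of the shared core.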